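The source may hold more compounds than are shown below. What is called first, only, known or untested is meant among the compounds shown, and "the series" means these compounds.

Compound 1 `O=C1N=C(N2N=C(c3ccccc3)CC2c2ccccc2O)S/C1=C1/C(=O)Nc2ccccc21` and compound 2 `O=C1N=C(N2N=C(c3ccccc3)CC2c2ccccc2O)S/C1=C1/C(=O)Nc2ccc(Br)cc21` share a core and differ in one place: bromo in place of hydrogen on an aromatic carbon. In a functional assay on cells (Leukemia cell, Homo sapiens) for cytotoxicity, read by sulforhodamine B assay, with a stated time of 48 h (a lower number here means a stronger inhibitor of growth, a higher number a weaker inhibitor of growth), compound 1 gives 3190 nM, while compound 2 gives 270 nM, so that this single change made a 12-fold lower number from compound 1 to compound 2 (1.07 log units; beyond the scatter). Compound 3 `COc1ccc(C2=NN(C3=NC(=O)/C(=C4\C(=O)Nc5ccccc54)S3)C(c3ccc(OC)cc3)C2)cc1` carries a different core; how the two cores differ is not broken down here. In this assay compound 3 gives 100000 nM, the highest number of the three measured. Compound 4 `COc1ccc(C2=NN(C3=NC(=O)/C(=C4\C(=O)Nc5ccc(Br)cc54)S3)C(c3ccc(OC)cc3)C2)cc1` is related to compound 3 by the same change: bromo in place of hydrogen on an aromatic carbon. A step in the same direction is expected for compound 4 because of a 12-fold lower number from compound 1 to compound 2 (1.07 log units; beyond the scatter), yet that step comes from one pair on one core. The expected step is therefore a 6.7-fold lower number from compound 3 to compound 4 (0.82 log units; beyond the scatter), smaller and less certain. Compound 4 is estimated at 15000 nM, likely between 3000 nM and 100000 nM.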

Compound 4, concentration for 50% growth inhibition: 280 nM
The estimate for compound 4 lay 54-fold (1.73 log units) above the measured number; the measured number lies below the stated range.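

In this assay bromo in place of hydrogen gave a 360-fold lower number from compound 3 to compound 4 (2.55 log units; beyond the scatter) and so lowered the number on this core as well, but not by the same amount: the same change on two cores in this assay, a 12-fold lower number (1.07 log units; beyond the scatter) from compound 1 to compound 2 and a 360-fold lower number (2.55 log units; beyond the scatter) from compound 3 to compound 4, 30-fold (1.48 log units) apart, beyond the scatter of two such steps The direction of the step carried over from one core to the other, while its size did not, so the size found on one core was a poor guide to the size on the other. Among these compounds, with only one pair on each core, these results do not show why the two steps differ or what the change would do on a further core. The compounds shown leave open whether chloro, methyl or an amine in the same place would lower the number as bromo does. They also leave open whether bromo elsewhere on that ring would have a similar effect.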